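A few compounds are considered here, and "the series" means these few. Any claim that something is new, unique, unknown or untested is made for them only; others in the source may bear on it.

Compound 1 `COc1ccc(-n2c(SCc3ccc(C)cc3)nnc2-c2cc(OC)c(OC)c(OC)c2)cc1`: 56500 nM
Compound 2 `COc1ccc(-n2c(SCC(=O)c3ccc(F)cc3)nnc2-c2cc(OC)c(OC)c(OC)c2)cc1`: 58300 nM
Compound 3 `COc1ccc(-n2c(SCC(=O)c3ccc(OC)c(O)c3)nnc2-c2cc(OC)c(OC)c(OC)c2)cc1`: > 60000 nM

These three values come from a functional assay on PC-3 cells (Homo sapiens) for inhibition, read by MTT assay, with a stated time of 48 h; on this read-out lower numbers stand for stronger inhibition and higher numbers for weaker inhibition. For compound 3, > 60000 nM is a limit of the assay and not a number.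

Compound 4 `COc1ccc(-n2c(SCC(=O)C3CC3)nnc2-c2cc(OC)c(OC)c(OC)c2)cc1` has cyclopropyl in place of 3-hydroxy-4-methoxyphenyl on a carbonyl carbon.

The closest measured change also swaps the group on a carbonyl carbon: an at least 1.0-fold higher number from compound 2 to compound 3 (0.01 log units; that floor lies within the scatter). The other two changes, a 1.0-fold higher number from compound 1 to compound 2 (0.01 log units; within the scatter) and an at least 1.0-fold higher number from compound 1 to compound 3 (0.02 log units; that floor lies within the scatter), also stay within the scatter, although the steps that end at compound 3 give only a floor.

On this basis, the expected change is no larger than the scatter: an at least 1.0-fold lower number from compound 3 to compound 4 (0.01 log units; that floor lies within the scatter). The estimate for compound 4 is 58000 nM, with an expected range of 35000 nM to 95000 nM.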

Compound 4, half-maximal inhibitory concentration: 37200 nM
The estimate for compound 4 lay 1.6-fold (0.19 log units) above the measured number; low and high end bracket the measured number.
By their numbers in this assay, from the lowest: compounds 4, 1 and 2 (each within the scatter of the next). At a limit, above all of these: compound 3.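

In this assay, cyclopropyl in place of 4-fluorophenyl on the carbonyl carbon gives a 1.6-fold lower number from compound 2 to compound 4 (0.20 log units; within the scatter), and cyclopropylcarbonyl in place of 4-methylphenyl on the saturated chain carbon bound to the sulfur gives a 1.5-fold lower number from compound 1 to compound 4 (0.18 log units; within the scatter). So a three-membered non-aromatic ring of carbon only fits at this position with the number staying within the scatter, whereas the earlier compounds carried only six-membered aromatic rings there. The step of an at least 1.6-fold lower number from compound 3 to compound 4 (0.20 log units; that floor lies within the scatter) gives only a floor, since compound 3 stands at a limit: the limit of > 60000 nM in this assay, at which 1 of the 4 values shown sits.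

As far as these compounds go, whether any group here can move the number beyond the scatter remains open. An amine, a carboxylic acid or a longer carbon chain on the carbonyl carbon would test that.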